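Ethyl ester versus free acid across two dimethoxy cores

This account rests on a few compounds, and the source may have more. Where it says the series, first, only, none or still open, it means among the compounds named here.

Cytotoxicity is followed in an ADME assay on MT4 cells (Homo sapiens) for cytotoxicity, read by MTT assay; on this read-out higher numbers stand for lower toxicity in this test and lower numbers for higher toxicity in this test. Compound 1 `COc1cc2c(C(=O)/C=C(\O)C(=O)O)cn(Cc3ccc(F)cc3)c2cc1OC` gives 65500 nM. Compound 2 `COc1cc(OC)c2c(c1)c(C(=O)/C=C(\O)C(=O)O)cn2Cc1ccc(F)cc1` carries the same atoms on a differently joined core; the difference between the two cores is not broken down here. In this assay compound 2 gives 58500 nM, which lies within the scatter of the number for compound 1. Compound 3 `CCOC(=O)/C(O)=C/C(=O)c1cn(Cc2ccc(F)cc2)c2cc(OC)c(OC)cc12` gives 21800 nM. The change from compound 1 to compound 3 is ethyl in place of hydrogen on an oxygen next to a carbonyl group, and it made a 3.0-fold lower number from compound 1 to compound 3 (0.48 log units; beyond the scatter).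

Compound 4 `CCOC(=O)/C(O)=C/C(=O)c1cn(Cc2ccc(F)cc2)c2c(OC)cc(OC)cc12` is not yet measured in this assay. It differs from compound 2 by ethyl in place of hydrogen on an oxygen next to a carbonyl group, the same change as from compound 1 to compound 3, made at the same place on the core of compound 2. Going by the values given here, the only guide to its size is the single step from compound 1 to compound 3, so the expectation rests on one pair; whether the core of compound 2 responds alike is not known from these compounds. The expected step is a 3.0-fold lower number from compound 2 to compound 4 (0.48 log units; beyond the scatter). Compound 4 is estimated at 19500 nM, with a range of 8000 nM to 45000 nM.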

Compound 4, half-maximal cytotoxic concentration: 62100 nM
Compound 4: the middle estimate sits 3.2-fold (0.50 log units) below what was measured, and the stated range ends below it.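

In this assay, the change from carboxy to ethoxycarbonyl on the core of compound 2 gives a 1.1-fold higher number from compound 2 to compound 4 (0.03 log units; within the scatter), so the ethyl ester and the free acid cannot be told apart on this core. Going by these compounds alone, the size of the step therefore does not carry over from one core to the other in this pair of cores: the same change on two cores in this assay, a 3.0-fold lower number (0.48 log units; beyond the scatter) from compound 1 to compound 3 and a 1.1-fold higher number (0.03 log units; within the scatter) from compound 2 to compound 4, 3.2-fold (0.50 log units) apart, beyond the scatter of two such steps With only one pair on each core, this does not show which feature of the two cores goes with the gap, nor which of the two steps would be the more usual one for this series.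

Still open, going by these compounds, is whether a methyl ester, a longer chain on the ester oxygen or an amide at the same place would follow the step seen on the core of compound 1 or the one seen on the core of compound 2. Equally open, on these data alone, is how a third core would respond to the same change from carboxy to ethoxycarbonyl.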